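This account rests on a few compounds, and the source may have more. Where it says the series, first, only, none or still open, it means among the compounds named here.

Measured so far in an ADME assay on CEM174 cells (Homo sapiens) for cytotoxicity (on this read-out higher numbers stand for lower toxicity in this test and lower numbers for higher toxicity in this test), both values being limits of the assay:
Compound 1 `Cc1ccccc1-c1cnnc(NCc2cc(-c3ccccc3)[nH]n2)n1` gives > 10000 nM
Compound 2 `Cc1ccccc1-c1cncc(NCc2cc(-c3ccccc3)[nH]n2)n1` gives > 10000 nM

Compound 1 stands at the limit of > 10000 nM in this assay, at which 2 of the 2 values shown sit. Compound 3 `Cc1cc(C#N)ccc1-c1cnnc(NCc2cc(-c3ccccc3)[nH]n2)n1` differs from compound 1 in one place, 2-methylphenyl to 4-cyano-2-methylphenyl: cyano in place of hydrogen on an aromatic carbon. For the measured compounds named here, the measured compounds offer no step that shows what this change does. The change expected in this assay is none beyond the scatter, and the estimate for a number no higher from compound 1 to compound 3 (the limit leaves the size open) follows that expectation. Compound 3 is expected at 10000 nM, with an estimated range of 4000 nM to 25000 nM.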

Compound 3, half-maximal cytotoxic concentration: > 10000 nM
Compound 3: only a limit was reported; the forecaster's own chance of this, stated with the estimate: 75%; the middle value lies on the limit itself.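

No step can be read from compound 1 to compound 3 in this assay, since both values are limits: the limit of > 10000 nM in this assay, at which 3 of the 3 values shown sit.

What cyano in place of hydrogen does in this assay stays open, as does how far any compound shown lies from that limit.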